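Shifting the methyl on the sulfonamide arene

This account rests on a few compounds, and the source may have more. Where it says the series, first, only, none or still open, it means among the compounds named here.

Compound 1, `Cc1cccc(-c2noc(C3CN(S(=O)(=O)c4cccc(C)c4)C3)n2)c1`: > 10000 nM (a limit of the assay)
Compound 2, `O=C(N1CCCCC1)N1CC(c2nc(-c3cccc(Cl)c3)no2)C1`: 370 nM
Compound 3, `Cc1cccc(S(=O)(=O)N2CC(c3nc(-c4cccc(Cl)c4)no3)C2)c1`: > 10000 nM (a limit of the assay)

All three were measured in an assay on HEK293 cells for positive allosteric modulation of metabotropic glutamate receptor 5 (Homo sapiens), read by FLIPR; on this read-out lower numbers stand for an effect already at smaller amounts and higher numbers for an effect only at larger amounts of compound. Compound 1 gives no number there, only the limit > 10000 nM. Compound 3 also stops at a limit, > 10000 nM. Among the measured compounds shown here, the two therefore sit together at the limit of > 10000 nM in this assay, at which 2 of the 3 values shown sit, and the only measured number belongs to compound 2, which carries a different group on the nitrogen of the shared core and gives 370 nM in this assay.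

For the measured compounds named here, the one step between compounds that differ in a single place is a step that the two limits leave unreadable from compound 1 to compound 3: both ends are limits, so its size cannot be read.

Compound 4, `Cc1ccc(S(=O)(=O)N2CC(c3nc(-c4cccc(C)c4)no3)C2)cc1`, differs from compound 1 by 4-methylphenyl in place of 3-methylphenyl on a sulfonyl sulfur. Going by the values given here, no measured step speaks to such a shift of the methyl; the closest relatives, compound 1 and compound 3, both sulfonamides on the same core, give only limits in this assay. It is therefore expected that compound 4 stays in the same place, with a step that the limit leaves unreadable from compound 1 to compound 4 that is none beyond the scatter. The estimate for compound 4 is 12000 nM, within 3000 nM to 40000 nM, most likely reported as a limit again.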

Compound 4, half-maximal effective concentration: > 10000 nM
Compound 4: a limit, no number; the forecaster's own chance of this, stated with the estimate: 75%; the middle value lies beyond the limit too.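

Compound 4 gives only a limit in this assay, > 10000 nM. Compound 1 also stops at a limit, so no step can be read between the two. The compounds shown leave open whether 4-methylphenyl and 3-methylphenyl on the sulfonyl sulfur differ at all, since neither compound gives a number in this assay.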